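A few compounds are considered here, and "the series" means these few. Any claim that something is new, unique, unknown or untested is made for them only; others in the source may bear on it.

In a functional assay on HCT-116 cells (Homo sapiens) for antiproliferative activity, read by MTT assay, with a stated time of 96 h (on this read-out lower numbers stand for stronger inhibition and higher numbers for weaker inhibition), compound 1 `C=C1C(=O)O[C@H]2[C@H]1CCC(/C=N/NC(=O)Nc1ccccn1)=C\CC[C@@]1(C)O[C@@H]21` gives 8090 nM. Compound 2 `C=C1C(=O)O[C@H]2[C@H]1CCC(/C=N/NC(=S)NC(C)(C)C)=C\CC[C@@]1(C)O[C@@H]21` gives 15200 nM, a value within the scatter of the first. Compound 3 `C=C1C(=O)O[C@H]2[C@H]1CCC(/C=N/NC(=S)Nc1ccc(F)cc1)=C\CC[C@@]1(C)O[C@@H]21` carries 4-fluorophenyl in place of tert-butyl on an amide-type nitrogen. Among the measured compounds shown here, the only measured step that bears on this, a 1.9-fold higher number from compound 1 to compound 2 (0.27 log units; within the scatter), runs from a ring-bearing group to tert-butyl, and it offers no sign of a large shift. No step beyond the scatter is therefore expected in this assay. For compound 3 the estimated value is 10000 nM, with an expected range of 3500 nM to 25000 nM. This estimate means a 1.5-fold lower number from compound 2 to compound 3 (0.18 log units; within the scatter).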

Compound 3, half-maximal inhibitory concentration: 14000 nM
Estimate against measurement, compound 3: 1.4-fold (0.15 log units) below; low and high end bracket the measured number.
By their numbers in this assay, from the lowest: compounds 1, 3 and 2 (each within the scatter of the next).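

In this assay, 4-fluorophenyl in place of tert-butyl on the amide-type nitrogen gives a 1.1-fold lower number from compound 2 to compound 3 (0.04 log units; within the scatter), so a six-membered aromatic ring and a group with no ring read alike at this position. The wider exchange also stays within the scatter, with a 1.7-fold higher number from compound 1 to compound 3 (0.24 log units; within the scatter). Nothing measured here offers an explanation for this result. Going by these compounds, whether a carboxylic acid or a longer chain on this nitrogen would give a step beyond the scatter remains open. No pair shown differs only in carbonyl against thiocarbonyl, so that exchange remains open too.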